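This account rests on a few compounds, and the source may have more. Where it says the series, first, only, none or still open, it means among the compounds named here.

Measured so far in a physicochemical assay for lipophilicity, read by HPLC, measured as chromatographic lipophilicity, at pH 7.4; a higher number here means a more lipophilic compound, a lower number a more polar compound:
compound 1 `CC(C)(CN)C(=O)N1N=CCC1c1ccccc1` — 1.4
compound 2 `O=C(c1cscn1)N1CCC(C(=O)N2N=CC[C@H]2c2ccccc2)CC1` — 3
compound 3 `CC1=NN(C(=O)C(C)(C)C)[C@H](c2ccccc2)C1` — 6.4

Compound 1 stands lowest of the three numbers in this assay. Its nearest neighbour is compound 2, whose value sits higher by a margin beyond the usual scatter; compound 3 lies furthest from compound 1, also beyond the scatter. Among the measured compounds shown here, no two of the measured compounds differ in only one place, so no measured single-site step is available as a guide.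

Compound 4 `O=C(c1cccnc1)N1N=CCC1c1ccccc1` has not yet been measured. It arises from compound 1 by one change: pyridin-3-yl in place of 1-(aminomethyl)-1-methylethyl on a carbonyl carbon The group that leaves carries a hydrogen-bond donor; the group that enters carries none. Among the measured compounds, the two without such a donor, compound 2 and compound 3, both sit higher than compound 1, and nothing in the set goes against that trend.

The step from compound 1 to compound 4 is therefore expected to be upward and beyond the scatter, a number 2.40 log units higher from compound 1 to compound 4 (beyond the scatter). For compound 4 the estimated value in this assay is 3.8, expected to fall between 3 and 4.6.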

Compound 4, distribution coefficient: 2.7
The estimate for compound 4 lay 1.10 log units above the measured number; the measured number lies below the stated range.
By their numbers in this assay, from the lowest: compound 1; then compounds 4 and 2 (each within the scatter of the next); then compound 3.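

With the core of compound 1 held fixed, the series now has its first single-site step in this assay: the exchange of 1-(aminomethyl)-1-methylethyl for pyridin-3-yl on a carbonyl carbon gives a number 1.30 log units higher from compound 1 to compound 4 (beyond the scatter), so this position responds measurably to the group it carries. The exchange removes the hydrogen-bond donor and introduces a six-membered aromatic ring together, so this step alone cannot apportion the change between those two differences. No measurement available here explains the size of the step.

Going by these compounds, it remains open whether an open-chain group with a hydroxymethyl in place of the aminomethyl would separate the loss of the amine from the gain of the ring. The dependence on the ring nitrogen's location is also unresolved, and pyridin-2-yl or pyridin-4-yl on the same carbonyl carbon would address it.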